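Propargylsulfanyl to methylsulfanyl on a chloro-alkynyl selenoquinoline

The compounds below may be only part of what the source reports. "The series", "measured", "known", "first", "only" and "open" are said of these compounds alone.

Measured compounds:
- compound 1 `C#CCSc1cnc2ccccc2c1[Se]CC#CCCl`: 3.2 ug/mL
- compound 2 `O=C(/C=C/c1ccccc1)OCC#CCSc1cnc2ccccc2c1Cl`: 48.8 ug/mL
- compound 3 `CSc1cnc2ccccc2c1[Se]CC#CCOC(=O)c1ccccc1`: 3.6 ug/mL

In a functional assay on SW707 cells (Homo sapiens) for antiproliferative activity, with a stated time of 72 h (on this read-out lower numbers stand for stronger inhibition and higher numbers for weaker inhibition), compound 1 gives 3.2 ug/mL, the lowest number among the three shown. Compound 3 gives 3.6 ug/mL, which lies within the scatter of compound 1, so no order between these two can be claimed. Compound 2 gives 48.8 ug/mL, beyond the scatter and well apart from compound 1.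

Compound 4 `CSc1cnc2ccccc2c1[Se]CC#CCCl` has not been measured. Relative to compound 1 it differs by hydrogen in place of ethynyl on a saturated chain carbon bound to a sulfur. Among the measured compounds shown here, no step between measured compounds isolates this change. The closeness of compound 1 and compound 3, which already carries methylsulfanyl on the shared core, suggests little shift. The step of a 1.1-fold higher number from compound 1 to compound 4 (0.04 log units; within the scatter) is therefore expected to stay within the scatter. Compound 4 is estimated at 3.5 ug/mL, with a range from 1.5 ug/mL to 9 ug/mL.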

Compound 4, concentration for 50% inhibition: 3.2 ug/mL
For compound 4 the middle estimate is 1.1-fold (0.04 log units) above the measured one, and the stated range covers the measured number.
By their numbers in this assay, from the lowest: compounds 1, 4 and 3 (each within the scatter of the next); then compound 2.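

In this assay, among the compounds shown here, hydrogen in place of ethynyl on a saturated chain carbon bound to a sulfur gives no change at the digits printed from compound 1 to compound 4 (within the scatter) and is the first step to isolate this change. With the rest of compound 1 held fixed, the ethynyl end of propargylsulfanyl is not needed for this read-out, and methylsulfanyl serves as well. Nothing measured here explains this.

On these data alone, whether a longer chain such as hexylsulfanyl, or an amine or carboxylic acid at the end of this chain, would keep the value remains open. Also open, as far as these compounds go, is whether this position is equally tolerant when the chlorine of the alkynyl chain is replaced.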